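This account rests on a few compounds, and the source may have more. Where it says the series, first, only, none or still open, it means among the compounds named here.

Of the compounds shown here, three built on one shared core have so far been measured in an assay on isolated protein for inhibition of histone deacetylase HD1B (Zea mays); on this read-out higher numbers stand for weaker inhibition and lower numbers for stronger inhibition. Compound 1 `Cn1cc(/C=C/C(=O)c2ccccc2)cc1/C=C/C(=O)NO` gives 260 nM, compound 2 `Cn1cc(/C=C/C(=O)c2ccccc2Cl)cc1/C=C/C(=O)NO` gives 1600 nM, and compound 3 `Cn1cc(/C=C/C(=O)c2ccc(F)cc2)cc1/C=C/C(=O)NO` gives 24900 nM. Compound 2 therefore holds the second highest of the three numbers: the step of a 6.2-fold higher number from compound 1 to compound 2 (0.79 log units; beyond the scatter) separates it from compound 1, and the step of a 16-fold higher number from compound 2 to compound 3 (1.19 log units; beyond the scatter) separates it from compound 3.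

Compound 4 `Cn1cc(/C=C/C(=O)c2cccs2)cc1/C=C/C(=O)NO` has not yet been measured. It differs from compound 2 in one place: thiophen-2-yl in place of 2-chlorophenyl on a carbonyl carbon. Among the measured compounds shown here, no measured step exchanges the group on the carbonyl carbon for a five-membered ring. The nearest guide is a 16-fold higher number from compound 2 to compound 3 (1.19 log units; beyond the scatter), which shows that altering this group can shift this assay by a large amount, while a 6.2-fold higher number from compound 1 to compound 2 (0.79 log units; beyond the scatter) and a 96-fold higher number from compound 1 to compound 3 (1.98 log units; beyond the scatter) show that the plain phenyl of compound 1 gives the lowest number. Thiophen-2-yl carries neither the chloro of compound 2 nor the fluoro of compound 3. On that basis compound 4 is expected to move towards the lower numbers, with an expected step of a 3.2-fold lower number from compound 2 to compound 4 (0.51 log units; beyond the scatter). The estimated value for compound 4 is 500 nM, within a range of 120 nM to 2500 nM.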

Compound 4, half-maximal inhibitory concentration: 25800 nM
For compound 4 the middle estimate is 52-fold (1.71 log units) below the measured one; the whole stated range lies below it.
By their numbers in this assay, from the lowest: compound 1; then compound 2; then compounds 3 and 4 (each within the scatter of the next).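

In this assay, thiophen-2-yl on the carbonyl carbon does not match the plain phenyl of compound 1 (a 99-fold higher number from compound 1 to compound 4 (2.00 log units; beyond the scatter)), and it also stands apart from 2-chlorophenyl (a 16-fold higher number from compound 2 to compound 4 (1.21 log units; beyond the scatter)). Set against 4-fluorophenyl, it makes no difference beyond the scatter (a 1.0-fold higher number from compound 3 to compound 4 (0.02 log units; within the scatter)), so among these compounds, a ring carrying neither chloro nor fluoro can still give a number far from that of compound 1, and plain phenyl alone holds the lowest number. Nothing given here explains these steps.

The compounds shown leave open whether the five-membered ring or its sulfur goes with the number of compound 4, which furan-2-yl, with oxygen in place of sulfur, could test. They also leave open how a pyridine ring or a saturated cyclohexyl would read on this carbonyl carbon.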